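Notes: 4-cyanophenyl to piperidin-4-yl on the series

The compounds below may be only part of what the source reports. "The series", "measured", "known", "first", "only" and "open" are said of these compounds alone.

Values so far in a physicochemical assay for solubility, read by nephelometry, at pH 7.4 (on this read-out lower numbers stand for lower solubility and higher numbers for higher solubility), are as follows:
- compound 1 `COc1cccc(NC(=O)c2nnn(CC3CCN(C(C)=O)CC3)c2N)c1` gives > 250000 nM as a limit
- compound 2 `COc1cccc(NC(=O)c2nnn(Cc3ccc([S+](C)[O-])cc3)c2N)c1` gives > 250000 nM as a limit
- compound 3 `COc1cccc(NC(=O)c2nnn(Cc3ccc(C#N)cc3)c2N)c1` gives 216000 nM as a number

Going by the values given here, compound 3 at 216000 nM holds the only true number in the set. The other entries stand at the limit of > 250000 nM in this assay, at which 2 of the 3 values shown sit, and so give no number.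

The change to compound 4 `COc1cccc(NC(=O)c2nnn(CC3CCNCC3)c2N)c1` is this: piperidin-4-yl in place of 4-cyanophenyl on a saturated chain carbon bound to an aromatic nitrogen and the rest of the structure stays the same.

Compound 1 carries 1-acetylpiperidin-4-yl in that same place, so the closest guide is an at least 1.1-fold lower number from compound 1 to compound 3 (0.06 log units; that floor lies within the scatter) and it runs opposite to the step in question. The nitrile end of compound 3 is also touched by an at least 1.1-fold lower number from compound 2 to compound 3 (0.06 log units; that floor lies within the scatter) as a second guide. Each of these is only a floor. The remaining step, a step that the two limits leave unreadable from compound 1 to compound 2 offers no size.

A small rise in this assay is therefore expected, with no firm case for a move beyond the scatter. The expected size is a 1.2-fold higher number from compound 3 to compound 4 (0.06 log units; within the scatter) as an estimate. The estimated value for compound 4 is 250000 nM with an expected range from 130000 nM to 450000 nM and a report as a limit is quite possible.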

Compound 4, solubility: > 250000 nM
Compound 4: no number, only a limit; the forecaster's own chance of this, stated with the estimate: 60%; the middle value sits exactly at the limit.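

In this assay, piperidin-4-yl in place of 4-cyanophenyl on a saturated chain carbon bound to an aromatic nitrogen gives an at least 1.1-fold higher number from compound 3 to compound 4 (0.06 log units; that floor lies within the scatter), so this direct comparison supplies only a floor and no size for the change. Compound 4 gives a limit and not a number, as does compound 1, so the non-aromatic ring at this place gives a limit with either hydrogen or acetyl on its amine nitrogen; compound 2 goes against any split by ring type, since it carries a six-membered aromatic ring and also gives a limit. The steps from compound 1 and from compound 2 to compound 4 cannot be read because both ends of each step are limits: the limit of > 250000 nM in this assay, at which 3 of the 4 values shown sit.

As far as these compounds go, whether the nitrile itself sets compound 3 apart from the other compounds stays open, and a plain phenyl ring or a carboxylic acid on that ring at the same place would bear on this. From the compounds shown here alone, whether a longer chain between the aromatic nitrogen and the piperidin-4-yl ring, or a methyl group on its amine nitrogen, would give a number in this assay also stays open.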